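A few compounds are considered here, and "the series" means these few. Any claim that something is new, unique, unknown or untested is made for them only; others in the source may bear on it.

Measured so far:
compound 1 `CN(C)CCn1cnnc1-c1cc(Oc2ccc(NC(=O)Nc3ccc(Cl)cc3Cl)cc2F)ccn1`, 10400 nM
compound 2 `CN(C)CCCn1cnnc1-c1cc(Oc2ccc(NC(=O)Nc3ccc(F)c(F)c3)cc2F)ccn1`, 15300 nM

In an ADME assay on WI-38 cells (Homo sapiens) for cytotoxicity, read by MTT assay, with a stated time of 72 h (on this read-out higher numbers stand for weaker inhibition and lower numbers for stronger inhibition), compound 2 gives the highest of the two numbers; its nearest neighbour is compound 1, and the gap between them lies within the scatter. Compound 3 `CN(C)CCCn1cnnc1-c1cc(Oc2ccc(NC(=O)Nc3ccc(Cl)cc3Cl)cc2F)ccn1` is not yet measured. It differs from compound 2 by 2,4-dichlorophenyl in place of 3,4-difluorophenyl on an amide-type nitrogen. Compound 1 already carries the 2,4-dichlorophenyl group and gives 10400 nM in this assay, which sits within the scatter of compound 2. No step beyond the scatter is therefore expected from compound 2 to compound 3. Compound 3 is expected to give 11000 nM, in the range 5000 nM to 25000 nM, meaning an estimated step of a 1.4-fold lower number from compound 2 to compound 3 (0.14 log units; within the scatter).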

Compound 3, half-maximal inhibitory concentration: 3260 nM
Compound 3: middle estimate off by 3.4-fold (0.53 log units), on the high side, and the stated range ends above it.
By their numbers in this assay, from the lowest: compound 3; then compounds 1 and 2 (each within the scatter of the next).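

In this assay, 2,4-dichlorophenyl in place of 3,4-difluorophenyl on an amide-type nitrogen gives a 4.7-fold lower number from compound 2 to compound 3 (0.67 log units; beyond the scatter) and so shows that this group matters when the chain is held fixed. Adding one chain unit, (dimethylamino)methyl in place of dimethylamino, gives a 3.2-fold lower number from compound 1 to compound 3 (0.50 log units; beyond the scatter) and shows that the chain matters too, which the close values of compound 1 and compound 2, differing in both places, had hidden. Nothing measured here explains either step. Still open, on these data alone, is whether a longer chain, or a morpholine in place of dimethylamino, moves the number further, and whether the aryl step holds on the shorter chain.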